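A few compounds are considered here, and "the series" means these few. Any claim that something is new, unique, unknown or untested is made for them only; others in the source may bear on it.

Working notes on the aminothiazolopyrimidinone series. Compound 1 `Cc1nc2sc(Nc3ccccc3)nc2c(=O)[nH]1` is the unsubstituted parent of the set; in an assay on CHO cells for displacement of a labelled ligand from adenosine receptor A3 (Homo sapiens), read by scintillation counting, with a stated time of 120 min, tested at 1 uM (on this read-out higher numbers stand for more inhibition at the one concentration tested (going by the name of the read-out) and lower numbers for less inhibition), compound 1 gives 45%. Among the three compounds measured so far compound 1 stands second highest, and both of its neighbours lie within the scatter of it. Compound 2 `COc1ccc(Nc2nc3c(=O)[nH]c(C)nc3s2)cc1` gives 36% in this assay, and compound 3 `Cc1ccc(Nc2nc3c(=O)[nH]c(C)nc3s2)cc1` gives 47%.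

For the measured compounds named here, the steps that bear on a change at the same aromatic ring are small. From compound 1 to compound 2 the change is a number 9 percentage points lower from compound 1 to compound 2 (within the scatter), and from compound 1 to compound 3 it is a number 2 percentage points higher from compound 1 to compound 3 (within the scatter). Going by the values given here, the only step that escapes the scatter is a number 11 percentage points higher from compound 2 to compound 3 (beyond the scatter), which remains modest.

Compound 4 `Cc1nc2sc(Nc3cccc(Cl)c3)nc2c(=O)[nH]1` is the next member: chloro in place of hydrogen on an aromatic carbon. The two substitutions of hydrogen on this ring seen so far shifted the read-out by amounts inside the scatter, so a chloro entering at this position is expected to do no more. The expected step in this assay is therefore a number 4 percentage points higher from compound 1 to compound 4 (within the scatter), that is, none beyond the scatter. Compound 4 is thus estimated at 49%, with a range from 32% to 66%.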

Compound 4, a percentage reported as inhibition, at one concentration (the size of the read-out at that concentration, not a potency): 48%
For compound 4 the middle estimate is 1 percentage points above the measured one; the measured number falls inside the stated range.
By their numbers in this assay, from the lowest: compounds 2, 1, 3 and 4 (each within the scatter of the next, the first and the last beyond it).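

Placed meta to a large group on the six-membered aromatic ring, chloro in place of hydrogen gives in this assay a number 3 percentage points higher from compound 1 to compound 4 (within the scatter) and so stays level with the parent. For the compounds shown here, this adds two things to the earlier steps: the set now includes a halogen, and a substituent at a place on the ring that the methoxy of compound 2 and the methyl of compound 3 do not occupy. No measurement here bears on why this step is so small.

The compounds shown leave open whether methoxy or methyl at this same place would also stay within the scatter of compound 1, and whether a group of a different kind there, such as an amine or a carboxylic acid, would produce a step beyond it. With a single concentration for each compound, they also leave open whether compound 1 and compound 4 would still match in potency, since a percentage at one concentration does not give a potency.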